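This account rests on a few compounds, and the source may have more. Where it says the series, first, only, none or still open, it means among the compounds named here.

In a physicochemical assay for metabolic stability, read by HPLC, at pH 7.4, tested at 100 uM (on this read-out higher numbers stand for a longer-lived compound and lower numbers for a shorter-lived compound), the measured compounds are these.

Compound 1 `CC(OC(=O)O[C@H]1CCCCc2ccccc21)OC(=O)C1=C(S[C@@H]2CN[C@H](C(=O)N(C)C)C2)[C@H](C)[C@@H]2[C@@H]([C@@H](C)O)C(=O)N12` gives 1.07 h
Compound 2 `C[C@@H](O)[C@H]1C(=O)N2C(C(=O)OCOC(=O)O[C@H]3CCCc4ccccc43)=C(S[C@@H]3CN[C@H](C(=O)N(C)C)C3)[C@H](C)[C@H]12` gives 0.0233 h
Compound 3 `C[C@@H](O)[C@H]1C(=O)N2C(C(=O)OCOC(=O)O[C@@H]3CCCc4ccccc43)=C(S[C@@H]3CN[C@H](C(=O)N(C)C)C3)[C@H](C)[C@H]12` gives 0.025 h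

Compound 3, at 0.025 h, lies level with compound 2 within the scatter, while compound 1, at 1.07 h, has the clearly higher number of the three. The next compound, compound 4 `C[C@@H](O)[C@H]1C(=O)N2C(C(=O)OCOC(=O)O[C@H]3CCc4ccccc43)=C(S[C@@H]3CN[C@H](C(=O)N(C)C)C3)[C@H](C)[C@H]12`, departs from compound 3 by the following change: 2,3-dihydro-1H-inden-1-yl in place of 1,2,3,4-tetrahydronaphthalen-1-yl on an oxygen next to a carbonyl group. In words, 2,3-dihydro-1H-inden-1-yl stands in place of 1,2,3,4-tetrahydronaphthalen-1-yl on an oxygen next to a carbonyl group.

Among the compounds with values here, only one measured step bears on this, and only indirectly. That step, a 1.1-fold higher number from compound 2 to compound 3 (0.03 log units; within the scatter), alters the same group, though it leaves the group's atoms and bonds untouched, as shown by the fact that compounds 2 and 3 differ only in the configuration as drawn. Within the data shown here, no measured step changes the group itself, so the size of a change of this kind is not known directly. With that single small step as the guide, no step beyond the scatter is expected in this assay, and no direction is favoured. The expected change is a 1.0-fold lower number from compound 3 to compound 4 (0.02 log units; within the scatter). For compound 4 the estimated half-life is 0.024 h, with an expected range from 0.012 h to 0.05 h.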

Compound 4, half-life: < 0.0167 h
Compound 4: a limit, no number; the forecaster's own chance of this, stated with the estimate: 3%; at least 1.4-fold (0.15 log units) between middle value and limit.
By their numbers in this assay, from the lowest: compounds 2 and 3 (each within the scatter of the next); then compound 1. At a limit, below all of these: compound 4.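

In this assay, within the data shown here, compound 4 reads only as a limit, < 0.0167 h, and this is the first reading here for a change in the atoms of the group on an oxygen next to a carbonyl group, not only in its configuration. Set against the two compounds carrying 1,2,3,4-tetrahydronaphthalen-1-yl, 2,3-dihydro-1H-inden-1-yl gives an at least 1.4-fold lower number from compound 3 to compound 4 (0.17 log units; that floor lies within the scatter) and an at least 1.3-fold lower number from compound 2 to compound 4 (0.14 log units; that floor lies within the scatter); neither floor clears the scatter, and the true size of either step may lie beyond what these floors show. The change of ring therefore has only a floor, whereas a 1.1-fold higher number from compound 2 to compound 3 (0.03 log units; within the scatter) is a measured step, and the sizes of the two cannot be set against each other.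

The compounds shown leave open what number compound 4 would give in this assay, and with it whether replacing the six-membered non-aromatic ring by the five-membered one moves the half-life beyond the scatter at all. Also open, on these data alone, is how a benzyl group or a plain cyclohexyl group would read on that same oxygen, in place of either fused ring group.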